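Shrinking the Ring on the Sulfur of a Shared Core

The compounds below may be only part of what the source reports. "The series", "measured", "known", "first", "only" and "open" are said of these compounds alone.

Within the data shown here, compound 2 `Cn1c(-c2ccc(NC(=O)CSc3nc4ccccc4s3)cc2)nc(-c2ccccc2)c1-c1ccccc1`, measured in a functional assay on MCF7 cells (Homo sapiens) for cytotoxicity, read by MTT assay, with a stated time of 24 h, tested at 6.4 ug/mL (on this read-out lower numbers stand for a weaker effect and higher numbers for a stronger effect at the one concentration tested), gives 27% and stands second highest of the three numbers so far. Compound 1 `Cn1c(-c2ccc(NC(=O)CSc3nc4ccccc4o3)cc2)nc(-c2ccccc2)c1-c1ccccc1` gives 42.3%, and compound 3 `Cn1c(-c2ccc(NC(=O)CSC3=NCCS3)cc2)nc(-c2ccccc2)c1-c1ccccc1` gives 18.6%. Compound 4 `Cn1ccnc1SCC(=O)Nc1ccc(-c2nc(-c3ccccc3)c(-c3ccccc3)n2C)cc1` differs from compound 2 in one place: 1-methyl-1H-imidazol-2-yl in place of 1,3-benzothiazol-2-yl on a sulfur. Among the measured compounds shown here, two measured steps bear on this change. The step of a number 15.3 percentage points lower from compound 1 to compound 2 (beyond the scatter) shows an exchange of the ring on the sulfur moving the read-out beyond the scatter, whereas the step of a number 8.4 percentage points lower from compound 2 to compound 3 (within the scatter), where a smaller ring enters on the same sulfur, stayed within the scatter. A smaller ring entering here is therefore expected to give a small step down in this assay, or none beyond the scatter. Compound 4 is estimated at 22%, between 10% and 35%, meaning an expected step of a number 5 percentage points lower from compound 2 to compound 4 (within the scatter).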

Compound 4, a percentage reported as activity, at one concentration (the size of the read-out at that concentration, not a potency): 27.2%
Compound 4: the middle estimate sits 5.2 percentage points below what was measured; the range from low to high includes it.
By their numbers in this assay, from the lowest: compounds 3, 2 and 4 (each within the scatter of the next); then compound 1.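

In this assay, 1-methyl-1H-imidazol-2-yl on this sulfur could not be told apart from 1,3-benzothiazol-2-yl, with a number 0.2 percentage points higher from compound 2 to compound 4 (within the scatter), or from the non-aromatic ring of compound 3, with a number 8.6 percentage points higher from compound 3 to compound 4 (within the scatter). Compound 1 alone stands apart, now also with a number 15.1 percentage points lower from compound 1 to compound 4 (beyond the scatter), so among these four the 1,3-benzoxazol-2-yl group gives the one number beyond the scatter of the others. Nothing available explains this separation. Going by these compounds, what remains open is how an open-chain group on the same sulfur, such as an amine or a carboxylic acid on a longer chain, would read.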